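The compounds below may be only part of what the source reports. "The series", "measured", "known", "first", "only" and "open" are said of these compounds alone.

Compound 1 `COc1cc2c(cc1OC)C(CC(N)=O)CC2` is tested in a functional assay on the whole organism (strain Swiss albino) for inhibition, with Mus musculus as the target, in the writhing test, with stated times of 60 min and 15 min, at a dose of 100 mg/kg by the oral route (on this read-out lower numbers stand for less inhibition and higher numbers for more inhibition at the one dose given (going by the name of the read-out)), where compound 1 gives 24.6%. That number is the second highest of three: compound 2 `CCNC(=O)CC1CCc2cc(OC)c(OC)cc21` gives 23.6%, a step of a number 1 percentage points lower from compound 1 to compound 2 (within the scatter), while compound 3 `COc1cc2c(cc1OC)C(CC(=O)N1CCCCC1)CC2` gives 44.7%. Compound 4 `COc1cc2c(cc1OC)C(CC(=O)N1CCOCC1)CC2` has not yet been measured. It differs from compound 1 in one place: morpholin-4-yl in place of amino on a carbonyl carbon. Going by the values given here, the steps that bear on this are the ones to compound 3, a number 20.1 percentage points higher from compound 1 to compound 3 (beyond the scatter) and a number 21.1 percentage points higher from compound 2 to compound 3 (beyond the scatter), which each placed a ring on the carbonyl carbon and raised inhibition by a modest amount beyond the scatter. A rise of similar or somewhat smaller size is therefore expected for compound 4, a number 15.4 percentage points higher from compound 1 to compound 4 (beyond the scatter). Compound 4 is estimated at 40%, with a range from 28% to 52%.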

Compound 4, a percentage reported as inhibition, in the whole organism at one dose (the size of the read-out at that dose, not a potency): 23.6%
The estimate for compound 4 lay 16.4 percentage points above the measured number; measured number outside the range, below it.
By their numbers in this assay, from the lowest: compounds 2, 4 and 1 (each within the scatter of the next); then compound 3.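

A ring on the carbonyl carbon does not lift inhibition by itself: with morpholin-4-yl the steps are a number 1 percentage points lower from compound 1 to compound 4 (within the scatter) and no change at the digits printed from compound 2 to compound 4 (within the scatter). The identity of the ring matters here, as morpholin-4-yl, which brings in a ring oxygen, in place of piperidin-1-yl gives a number 21.1 percentage points lower from compound 3 to compound 4 (beyond the scatter). Nothing measured here explains this difference between the two rings.

Whether the higher number needs a six-membered ring stays open, as a pyrrolidin-1-yl group does not appear among these compounds. A piperazin-1-yl group, with a ring nitrogen where morpholin-4-yl has its oxygen, would also be informative.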